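Sulfonamide benzamides on a pyrazole nitrogen: methyl to methoxyphenyl

This account rests on a few compounds, and the source may have more. Where it says the series, first, only, none or still open, it means among the compounds named here.

Measured compounds:
compound 1 `Cn1cc(NC(=O)c2cccc(NS(=O)(=O)c3ccccc3)c2)cn1` – > 100000 nM, a limit of the assay
compound 2 `Cn1cc(NC(=O)c2ccc(NS(=O)(=O)c3ccccc3)cc2)cn1` – > 100000 nM, a limit of the assay

In a functional assay on A549 cells (Homo sapiens) for inhibition, read by MTT assay, with a stated time of 48 h (on this read-out lower numbers stand for stronger inhibition and higher numbers for weaker inhibition), compound 1 gives only > 100000 nM, which is a limit and not a number. Compound 2 likewise gives > 100000 nM, again a limit. Going by the values given here, compound 2 therefore stands at the limit of > 100000 nM in this assay, at which 2 of the 2 values shown sit, with no measured step to guide the next change. Compound 3 `COc1cccc(-n2cc(NC(=O)c3ccc(NS(=O)(=O)c4ccccc4)cc3)cn2)c1` carries 3-methoxyphenyl in place of methyl on an aromatic nitrogen. Among the compounds with values here, with no step between measured compounds available, no shift beyond the scatter is foreseen in this assay. Compound 3 is expected at 90000 nM, within 20000 nM to 300000 nM, meaning an estimated step of an at least 1.1-fold lower number from compound 2 to compound 3 (0.04 log units; that floor lies within the scatter).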

Compound 3, half-maximal inhibitory concentration: > 100000 nM
Compound 3 gave a limit, no number; the forecaster's own chance of this, stated with the estimate: 65%; middle value at least 1.1-fold (0.04 log units) away from the limit.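

In this assay compound 3 gives > 100000 nM, a limit and not a number. Going by these compounds alone, compound 2 also stands at a limit, so no step from compound 2 to compound 3 can be read. The compounds shown leave open how 3-methoxyphenyl in place of methyl changes inhibition, and they offer no number to compare: the limit of > 100000 nM in this assay, at which 3 of the 3 values shown sit.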